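Shortening the chain: compound 1 to compound 4

A few compounds are considered here, and "the series" means these few. Any claim that something is new, unique, unknown or untested is made for them only; others in the source may bear on it.

In an ADME assay on microsomes from liver (Homo sapiens) for metabolic stability, using NADPH, with a stated time of 10 min (a lower number here means that less of the compound is left, a higher number that more of the compound is left), compound 1 (`NCCCCN(C[C@H]1Cc2ncccc2CN1)[C@H]1CCCc2cccnc21`) gives 100%, compound 2 (`NCCCCN(C[C@@H]1Cc2ncccc2CN1)[C@H]1CCCc2cccnc21`) gives 98% and compound 3 (`NCCCCN(C[C@@H]1Cc2cccnc2CN1)[C@H]1CCCc2cccnc21`) gives 92%, all within the scatter of one another. Compound 4 (`CN(C[C@H]1Cc2ncccc2CN1)[C@H]1CCCc2cccnc21`) carries methyl where compound 1 carries 4-aminobutyl: hydrogen in place of 3-aminopropyl on a saturated chain carbon bound to an amine nitrogen. Among the compounds with values here, the only measured step, a number 2 percentage points lower from compound 1 to compound 2 (within the scatter), is a change of configuration that leaves this chain untouched, so it gives no direct size for the new change. Within the data shown here, all three measured compounds carry the same chain, and no measurement yet covers its removal. The expected step is a number 8 percentage points lower from compound 1 to compound 4 (within the scatter), with no shift beyond the scatter anticipated, although a lower number remains possible. For compound 4, the estimate is 92%, with an expected range from 74% to 100%.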

Compound 4, percent of the compound remaining: 95%
Compound 4: the middle estimate sits 3 percentage points below what was measured; low and high end bracket the measured number.
By their numbers in this assay, from the lowest: compounds 3, 4, 2 and 1 (each within the scatter of the next).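

Replacing 3-aminopropyl with hydrogen on a saturated chain carbon bound to an amine nitrogen gives a number 5 percentage points lower from compound 1 to compound 4 (within the scatter) in this assay. Within the data shown here, compounds 1, 2 and 3 all carry the 4-aminobutyl chain, so this is the first reading with methyl at this position, and the shortening moves the number no further than the scatter. No measured property available here bears on this step.

Open, on these data alone, is whether a longer chain or a carboxylic acid at the chain end would also stay within the scatter. Also open, as far as these compounds go, is how methyl reads on the cores of compound 2 and compound 3.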